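Methoxy in place of hydrogen on the phenyl of compound 3

A few compounds are considered here, and "the series" means these few. Any claim that something is new, unique, unknown or untested is made for them only; others in the source may bear on it.

Three members of this series have been run through a functional assay on MCF7 cells (Homo sapiens) for cytotoxicity, read by MTT assay, with a stated time of 24 h; on this read-out lower numbers stand for stronger inhibition and higher numbers for weaker inhibition. Compound 1 `Cc1ccc(-c2nnc(N3CCN(C(=O)CN4CCN(c5ccccc5)CC4)CC3)nc2-c2ccc(C)cc2)cc1` gives 914000 nM in this assay. Compound 2 `COc1ccc(-c2nnc(N3CCN(C(=O)CN4CCN(c5cccc(Cl)c5)CC4)CC3)nc2-c2ccc(OC)cc2)cc1` does not reach a number in this assay; its entry, > 814000 nM, is a limit of the assay. Compound 3 `O=C(CN1CCN(c2ccccc2)CC1)N1CCN(c2nnc(-c3ccc(Cl)cc3)c(-c3ccc(Cl)cc3)n2)CC1` likewise returns only a limit of the assay in this assay, > 850000 nM, and no number. So compound 3 stands where nothing is resolved: its own value is a limit (the limit of > 850000 nM in this assay, at which 1 of the 3 values shown sits), and one further value shown is a limit as well (the limit of > 814000 nM in this assay, at which 1 of the 3 values shown sits). No pair of these compounds differs in a single place, so no measured step within the series can be quoted.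

Compound 4 `COc1ccccc1N1CCN(CC(=O)N2CCN(c3nnc(-c4ccc(Cl)cc4)c(-c4ccc(Cl)cc4)n3)CC2)CC1` is the next compound in line. It differs from compound 3 by methoxy in place of hydrogen on an aromatic carbon, which turns phenyl into 2-methoxyphenyl. Going by the values given here, with no measured step to lean on, the expectation for this assay is a step from compound 3 to compound 4 of no size beyond the scatter, in no particular direction, a step that the limit leaves unreadable from compound 3 to compound 4. On that basis compound 4 is estimated at 900000 nM in this assay, in a range from 350000 nM to 2500000 nM, with a fair chance that it again returns only a limit.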

Compound 4, half-maximal inhibitory concentration: 330000 nM
For compound 4 the middle estimate is 2.7-fold (0.44 log units) above the measured one, outside the stated range (below it).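

Going by these compounds alone, the change from phenyl to 2-methoxyphenyl, ortho to a large group, gives the first readable step in this assay: an at least 2.5-fold lower number from compound 3 to compound 4 (0.41 log units; beyond the scatter), so this position of the terminal ring can move the read-out beyond the scatter. Compound 4 returns an actual number, 330000 nM, which gives the series a resolved value carrying the same two chlorophenyl groups as compound 3. The step sets only a minimum size and its true size stays unknown, because the value of compound 3 is a limit of the assay and not a number: the limit of > 850000 nM in this assay, at which 1 of the 4 values shown sits.

The compounds shown leave open whether the step belongs to methoxy in particular, or whether a hydroxyl, an amine or a longer chain such as ethoxy on the same aromatic carbon would lower the number to a similar degree. They also do not settle whether methoxy elsewhere on that ring would do the same, or whether this change would have a similar effect on the core of compound 1.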